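Longer chain on the shared core: expecting compound 4

The source may report more compounds than this note shows. Statements on the series, on what has been measured and on what is new or still open speak of the compounds shown alone.

Compound 1 `CCCCCCC(=O)c1cc(O)c(O)c(O)c1` reaches only the limit > 299000 nM in a toxicity assay on Vero cells (Chlorocebus sabaeus); a higher number here means a weaker inhibitor, a lower number a stronger inhibitor. Compound 2 `CCCCCCCCCCC(=O)c1cc(O)c(O)c(O)c1` likewise stands at the limit > 299000 nM in this assay. Compound 3 `CCCCCCCCCCCC(=O)c1cc(O)c(O)c(O)c1` also sits at the limit > 299000 nM in this assay.

Compound 3 thus stands at a limit rather than a number, and the two further values shown are limits as well (the limit of > 299000 nM in this assay, at which 3 of the 3 values shown sit). Compound 4 `CCCCCCCCCCCCCCCCC(=O)c1cc(O)c(O)c(O)c1` differs from compound 3 by pentyl in place of hydrogen on a saturated chain carbon, ten or more bonds along the chain from a carbonyl carbon. The measured steps that bear on this change are a step that the two limits leave unreadable from compound 2 to compound 3, a step that the two limits leave unreadable from compound 1 to compound 3 and a step that the two limits leave unreadable from compound 1 to compound 2; none of them has a readable size, so no direction beyond the scatter can be read from them. With three limits and no readable step, compound 4 is expected to remain at the limit, which means an estimated step that the limit leaves unreadable from compound 3 to compound 4. For compound 4 the estimate is 400000 nM, within 200000 nM to 2000000 nM.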

Compound 4, half-maximal inhibitory concentration: > 299000 nM
Compound 4: only a limit was reported; the forecaster's own chance of this, stated with the estimate: 85%; the middle value is on the limit's open side.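

In this assay compound 4 gives > 299000 nM, which is a limit. The steps to compound 4 from compound 2 and compound 3 therefore cannot be read. The compounds shown leave open whether chain length on the shared core matters at all in this assay: the limit of > 299000 nM in this assay, at which 4 of the 4 values shown sit.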